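This account rests on a few compounds, and the source may have more. Where it says the series, first, only, none or still open, it means among the compounds named here.

Compound 1, `C=CCn1c(SCC(=O)Nc2ccc(/C(C)=N/O)cc2)nnc1-c1ccc(OC)cc1`, compound 2, `C=CCn1c(SCC(=O)Nc2ccc(C(C)=O)cc2)nnc1-c1ccc(OC)cc1`, and compound 3, `CCn1c(SCC(=O)Nc2ccc(/C(C)=N/O)cc2)nnc1-c1ccccc1`, were all tested in a functional assay on the whole organism (strain albino) for inhibition, with Rattus norvegicus as the target, read by paw edema, with stated times of 30 min and 4 h, at a dose of 0.28 mmol/kg by the oral route; a lower number here means less inhibition, a higher number more inhibition at the dose given (going by the name of the read-out). In that setting compound 1 gives 75%, compound 2 gives 68%, and compound 3 gives 77%. Compound 1 and compound 2 differ in one place: a group of 3 heavy atoms (2 carbon, 1 oxygen; no ring) in place of a group of 4 heavy atoms (2 carbon, 1 nitrogen, 1 oxygen; no ring), on an aromatic carbon. This change made a step of a number 7 percentage points lower from compound 1 to compound 2 (within the scatter). Compound 3 and compound 1 share a common backbone but have different cores; the difference between the two cores is not broken down here. The values of compound 3 and compound 1 lie within the usual scatter of each other, as do those of compound 3 and compound 2, so no order among the three can be claimed.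

Compound 4, `CCn1c(SCC(=O)Nc2ccc(C(C)=O)cc2)nnc1-c1ccccc1`, has not yet been measured in this assay. It differs from compound 3 by a group of 3 heavy atoms (2 carbon, 1 oxygen; no ring) in place of a group of 4 heavy atoms (2 carbon, 1 nitrogen, 1 oxygen; no ring), on an aromatic carbon, the same change as from compound 1 to compound 2, made on the core of compound 3 instead. Because the earlier change made a step of a number 7 percentage points lower from compound 1 to compound 2 (within the scatter), the step from compound 3 to compound 4 is expected to be about a number 7 percentage points lower from compound 3 to compound 4 (within the scatter). Compound 4 is therefore estimated at 70%, with a likely range from 60% to 80%.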

Compound 4, a percentage reported as inhibition, in the whole organism at one dose (the size of the read-out at that dose, not a potency): 69%
Compound 4: the middle estimate sits 1 percentage points above what was measured; the measured number falls inside the stated range.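

In this assay, acetyl in place of the group of 4 heavy atoms, on an aromatic carbon para to a large group, gave a step of a number 8 percentage points lower from compound 3 to compound 4 (within the scatter), and the two cases of this change agree: the same change on two cores in this assay, a number 7 percentage points lower (within the scatter) from compound 1 to compound 2 and a number 8 percentage points lower (within the scatter) from compound 3 to compound 4, 1 percentage points apart, within the scatter of two such steps The change therefore carried over between these two cores with a step of much the same size, and the core of compound 1 and the core of compound 3 gave no sign of treating it differently. It does not show that the change truly lowers inhibition, as each step alone lies within the usual scatter, and two cores cannot show that the agreement would hold on any other core in the series.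

The compounds shown leave open what an amine or a carboxylic acid would give on that aromatic carbon in place of acetyl. They also leave open how a longer chain elsewhere on the shared backbone would bear on this step.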